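Swapping bromo for fluoro on a weak antiproliferative compound

A few compounds are considered here, and "the series" means these few. Any claim that something is new, unique, unknown or untested is made for them only; others in the source may bear on it.

Compound 1 `Nc1ccccc1NC(=O)c1ccc(COc2ccc(Br)cc2)cc1`: > 32000 nM
Compound 2 `Nc1ccccc1NC(=O)c1ccc(CN2CCc3cc(Br)ccc32)cc1`: 10700 nM

In a functional assay on HepG2 cells (Homo sapiens) for antiproliferative activity, read by CCK-8 assay, with a stated time of 72 h (on this read-out lower numbers stand for stronger inhibition and higher numbers for weaker inhibition), compound 1 gives > 32000 nM, which is a limit of the assay and not a number. Compound 1 stands at the limit of > 32000 nM in this assay, at which 1 of the 2 values shown sits. Compound 3 `Nc1ccccc1NC(=O)c1ccc(COc2ccc(F)cc2)cc1` differs from compound 1 in one place: fluoro in place of bromo on an aromatic carbon. This puts fluoro in place of bromo on an aromatic carbon, para to a large group. Among the measured compounds shown here, no measured pair shows what this swap does, so in this assay no step beyond the scatter is expected, and no direction can be favoured. The assay may again report only a limit. The estimated change is a number no higher from compound 1 to compound 3 (the limit leaves the size open). For compound 3 the expected value is 32000 nM, with an estimated range from 14000 nM to 60000 nM.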

Compound 3, half-maximal inhibitory concentration: 3840 nM
For compound 3 the middle estimate is 8.3-fold (0.92 log units) above the measured one; the measured number lies below the stated range.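

In this assay, the change from 4-bromophenoxy to 4-fluorophenoxy gives an at least 8.3-fold lower number from compound 1 to compound 3 (0.92 log units; beyond the scatter) and replaces a limit with a measured number. So this position responds to the choice of halogen, even though the swap leaves the ring and hydrogen-bond counts unchanged. From the compounds shown here alone, compound 1 gives > 32000 nM, which is a limit of the assay and not a number, so the full size of the step stays open: the limit of > 32000 nM in this assay, at which 1 of the 3 values shown sits.

The compounds shown leave open how chloro, methoxy or plain hydrogen would behave at this position. They also leave open whether fluoro in place of bromo would act the same way on the core of compound 2.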